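This account rests on a few compounds, and the source may have more. Where it says the series, first, only, none or still open, it means among the compounds named here.

Measured so far:
compound 1 `N#CCOc1ccc2nccc(SC3(C(=O)O)CCC3)c2c1` — 680 nM
compound 2 `COCCOc1ccc2nccc(SC3(C(=O)O)CCC3)c2c1` — 207 nM
compound 3 `COCc1ccc2nccc(SC3(C(=O)O)CCC3)c2c1` — 198 nM

All three share one core and differ only in the substituent on the aromatic ring. In an assay on HEK293 cells for inhibition of solute carrier family 22 member 12 (Homo sapiens), read by scintillation counting, with a stated time of 12 min (on this read-out higher numbers stand for weaker inhibition and lower numbers for stronger inhibition), compound 1 gives 680 nM, compound 2 gives 207 nM and compound 3 gives 198 nM. Within the data shown here, compound 3 thus carries the lowest number of the three, but its gap to compound 2 lies within the scatter, so the two cannot be ordered; only the step of a 3.4-fold lower number from compound 1 to compound 3 (0.54 log units; beyond the scatter) is clearly beyond the scatter, as is a 3.3-fold lower number from compound 1 to compound 2 (0.52 log units; beyond the scatter).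

Compound 4 `Cc1ccc2nccc(SC3(C(=O)O)CCC3)c2c1` is the next member: hydrogen in place of methoxy on a saturated chain carbon bound to an aromatic carbon. Among the measured compounds shown here, no measured step removes an ether oxygen from a side chain, so the precedent is indirect. The step of a 1.0-fold lower number from compound 2 to compound 3 (0.02 log units; within the scatter) shows that moving the methoxy-bearing chain from an oxygen-linked to a carbon-linked attachment changes nothing, whereas a 3.3-fold lower number from compound 1 to compound 2 (0.52 log units; beyond the scatter) and a 3.4-fold lower number from compound 1 to compound 3 (0.54 log units; beyond the scatter) show that exchanging a nitrile-containing substituent for a methoxy-containing one lowers the number modestly. Losing the methoxy altogether is therefore expected to cost a little, if anything, with a step of a 1.8-fold higher number from compound 3 to compound 4 (0.25 log units; within the scatter) in this assay. Compound 4 is estimated at 350 nM, range 150 nM to 900 nM.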

Compound 4, half-maximal inhibitory concentration: 343 nM
Estimate against measurement, compound 4: 1.0-fold (0.01 log units) above; the range from low to high includes it.
By their numbers in this assay, from the lowest: compounds 3, 2, 4 and 1 (each within the scatter of the next, the first and the last beyond it).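

In this assay the methoxy on a saturated chain carbon bound to an aromatic carbon can be removed, taking methoxymethyl to methyl, with a 1.7-fold higher number from compound 3 to compound 4 (0.24 log units; within the scatter) as the result, so no contribution of this methoxy and its single hydrogen-bond acceptor can be read from this pair. The methyl group also stays unresolved from the 2-methoxyethoxy group, with a 1.7-fold higher number from compound 2 to compound 4 (0.22 log units; within the scatter) as the reading, and from the cyanomethoxy group, with a 2.0-fold lower number from compound 1 to compound 4 (0.30 log units; within the scatter) as the reading, so compound 4 falls within the scatter of all three earlier compounds even though compound 1 stands clearly apart from compound 2 and compound 3. The series therefore does not show whether the ether oxygen or the nitrile accounts for that earlier separation, and the data offer no independent measurement that would explain these readings.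

Still open, going by these compounds, is how a hydrogen, an amine, a carboxylic acid or a longer chain such as propyl on this aromatic carbon would read in this assay when compared with the methyl group. Also open, on these data alone, is whether any such group would move beyond the scatter of compound 4 in either direction.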